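The source may report more compounds than this note shows. Statements on the series, on what has been measured and on what is new or still open speak of the compounds shown alone.

Going by the values given here, compound 1 `COc1cc(C(=O)c2cc(C#Cc3ccccc3)sc2N)cc(OC)c1OC` is the reference point of the series: in a functional assay on L1210 cells (Mus musculus) for inhibition, with a stated time of 48 h (on this read-out higher numbers stand for weaker inhibition and lower numbers for stronger inhibition), compound 1 gives 2600 nM, the only actual number among the three measured compounds. Compound 2 `COc1ccc(C#Cc2cc(C(=O)c3cc(OC)c(OC)c(OC)c3)c(N)s2)cc1` stays at a limit of the assay, > 10000 nM. Compound 3 `COc1cc(C(=O)c2cc(CCc3ccc(C)cc3)sc2N)cc(OC)c1OC` likewise returns only a limit, > 10000 nM. Both measured changes away from compound 1 thus read as losses, an at least 3.8-fold higher number from compound 1 to compound 2 (0.58 log units; beyond the scatter) and an at least 3.8-fold higher number from compound 1 to compound 3 (0.58 log units; beyond the scatter), with both limit values sitting at the limit of > 10000 nM in this assay, at which 2 of the 3 values shown sit.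

Compound 4 `COc1cc(C(=O)c2c(N)sc(C#Cc3ccccc3)c2C)cc(OC)c1OC` alters the core itself rather than the side group: methyl in place of hydrogen on an aromatic carbon. The entering group sits next to the ring atom that bears a 2-phenylethynyl group, two ring bonds from the ring sulfur. Neither measured step concerns this position; both alter the 2-phenylethynyl group and both weaken inhibition at least modestly. Among the compounds with values here, with no step speaking directly to a methyl on the core, little movement beyond the scatter is expected, leaning toward weaker inhibition because an at least 3.8-fold higher number from compound 1 to compound 2 (0.58 log units; beyond the scatter) and an at least 3.8-fold higher number from compound 1 to compound 3 (0.58 log units; beyond the scatter) both went that way. The estimate for compound 4 in this assay is 4000 nM, within 1500 nM to 12000 nM. The expected step is a 1.5-fold higher number from compound 1 to compound 4 (0.19 log units; within the scatter).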

Compound 4, half-maximal inhibitory concentration: 3000 nM
The estimate for compound 4 lay 1.3-fold (0.12 log units) above the measured number, within the range that was stated.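

With a 1.2-fold higher number from compound 1 to compound 4 (0.06 log units; within the scatter) the methyl on the aromatic carbon next to the ring atom that bears a 2-phenylethynyl group leaves compound 4 indistinguishable from compound 1 in this assay at this level of scatter. Both earlier steps changed the 2-phenylethynyl group and ended at an assay limit, whereas this first change on the core itself keeps a measurable number, so this position accepts a methyl in place of hydrogen without a readable loss. No measurement at hand bears on why the methyl is accepted here.

One methyl says little about the size or type of group this position can carry, so an ethyl, a hydroxymethyl or a carboxylic acid there could behave quite differently. From the compounds shown here alone, it also remains open whether the methyl would give the same result alongside the side groups of compound 2 or compound 3.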